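This account rests on a few compounds, and the source may have more. Where it says the series, first, only, none or still open, it means among the compounds named here.

Compound 2 `CSc1ccccc1C(=O)Nc1sc2c(c1C(N)=O)CCN(C(=S)Nc1ccccc1Cl)C2` gives 30500 nM in a functional assay on HL-60 cells (Homo sapiens) for antiproliferative activity, with a stated time of 24 h; a lower number here means a stronger inhibitor, a higher number a weaker inhibitor; compound 1 `COc1ccccc1C(=O)Nc1sc2c(c1C(N)=O)CCN(C(=S)Nc1ccccc1Cl)C2` gives 20800 nM, and the step of a 1.5-fold higher number from compound 1 to compound 2 (0.17 log units; within the scatter) lies within the scatter, so the two sit together and compound 2 has no neighbour clearly apart from it. Compound 3 `Cc1ccc(C(=O)Nc2sc3c(c2C(N)=O)CCN(C(=S)Nc2ccccc2Cl)C3)cc1` differs from compound 2 by 4-methylphenyl in place of 2-(methylsulfanyl)phenyl on a carbonyl carbon. Among the compounds with values here, the only measured step at that ring is the one just named; it kept the ring and exchanged one substituent for another, and it stayed within the scatter, so it offers little guide to replacing the whole ring. On that basis the expected step is a 1.2-fold lower number from compound 2 to compound 3 (0.09 log units; within the scatter), with no movement beyond the scatter anticipated. Compound 3 is estimated at 25000 nM, within a range from 7000 nM to 90000 nM.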

Compound 3, half-maximal inhibitory concentration: 8430 nM
Estimate against measurement, compound 3: 3.0-fold (0.47 log units) above, and the stated range covers the measured number.
By their numbers in this assay, from the lowest: compound 3; then compounds 1 and 2 (each within the scatter of the next).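

Exchanging the whole ring on the carbonyl carbon moves the number in this assay beyond the scatter, which the methylsulfanyl-for-methoxy exchange did not: a 3.6-fold lower number from compound 2 to compound 3 (0.56 log units; beyond the scatter), and a 2.5-fold lower number from compound 1 to compound 3 (0.39 log units; beyond the scatter). Thus 4-methylphenyl gives a modestly lower number than both 2-(methylsulfanyl)phenyl and 2-methoxyphenyl, so this position responds to the change of ring more than to the earlier exchange of substituent. No supporting data bear on the reason for this shift.

The substituent and its place on the ring change together here, so the contribution of each remains unresolved. Also open, going by these compounds, is how an unsubstituted phenyl or a ring bearing an amine would compare.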